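Furan methyl removal in a benzimidazole-hydrazone cytotoxicity series

The source may report more compounds than this note shows. Statements on the series, on what has been measured and on what is new or still open speak of the compounds shown alone.

Measured compounds:
compound 1 `Cc1ccc(-c2nc3ccccc3n2CC(=O)N/N=C/c2ccccc2Cl)o1` — 21300 nM
compound 2 `N=C(Cn1c(-c2ccco2)nc2ccccc21)NN` — 53100 nM
compound 3 `Cc1ccc(-c2nc3ccccc3[nH]2)o1` — 55600 nM

In a functional assay on MCF7 cells (Homo sapiens) for cytotoxicity, read by sulforhodamine B assay, with a stated time of 48 h (on this read-out lower numbers stand for stronger inhibition and higher numbers for weaker inhibition), compound 1 gives the lowest of the three numbers. Compound 2 and compound 3 show numbers beyond the scatter above it, so compound 1 is the strongest inhibitor among those measured. Compound 2 and compound 3 lie within the scatter of each other and are not ranked against one another.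

Compound 4 `O=C(Cn1c(-c2ccco2)nc2ccccc21)N/N=C/c1ccccc1Cl` has not yet been measured in this assay. It differs from compound 1 in one place: hydrogen in place of methyl on an aromatic carbon. The hydrazone part carrying the chlorophenyl group and the shared core are kept unchanged.

Among the compounds with values here, no measured pair isolates this change, so its size is unknown. The expectation is a small step from compound 1 to compound 4, toward a slightly higher number or none beyond the scatter, since the change removes only a single carbon at the edge of the molecule. Compound 4 is estimated at 30000 nM, with a range of 10000 nM to 90000 nM; the step of a 1.4-fold higher number from compound 1 to compound 4 (0.15 log units; within the scatter) is expected to stay close to the scatter of this assay.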

Compound 4, half-maximal inhibitory concentration: 26100 nM
For compound 4 the middle estimate is 1.1-fold (0.06 log units) above the measured one; the measured number falls inside the stated range.
By their numbers in this assay, from the lowest: compounds 1 and 4 (each within the scatter of the next); then compounds 2 and 3 (each within the scatter of the next).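

In this assay, the change from 5-methylfuran-2-yl to furan-2-yl gives a 1.2-fold higher number from compound 1 to compound 4 (0.09 log units; within the scatter) on the scaffold with the chlorophenyl hydrazone part. Within the data shown here, this pair is the first to isolate the position, the aromatic carbon next to the ring oxygen of the furan, and it shows that replacing the methyl with hydrogen there produces no step that can be told from the scatter. Nothing available on the compounds bears on this result.

On these data alone, whether an amine, a carboxylic acid or a longer chain such as propyl at this furan carbon would give a step beyond the scatter remains open. Also open, as far as these compounds go, is whether the methyl-to-hydrogen change reads the same once the hydrazone part carrying the chlorophenyl group is replaced.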